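Swapping chloro for methyl on the thiourea phenyl

The compounds below may be only part of what the source reports. "The series", "measured", "known", "first", "only" and "open" are said of these compounds alone.

Compound 3, `O=C(NC(=S)Nc1ccccc1Cl)Nc1ccc2c(c1)C(=O)C(=O)N2Cc1ccccc1Cl`, gives 3.98 in a physicochemical assay for lipophilicity, in phosphate buffer, measured as octanol-water partition (on this read-out higher numbers stand for higher lipophilicity and lower numbers for lower lipophilicity), the highest of the three numbers measured. Its nearest neighbour is compound 2, `O=C(NC(=S)Nc1ccccc1)Nc1ccc2c(c1)C(=O)C(=O)N2Cc1ccccc1Cl`, which gives 3.18, and the furthest is compound 1, `Cc1ccccc1NC(=S)NC(=O)Nc1ccc2c(c1)C(=O)C(=O)N2Cc1ccccc1`, which gives 2.98. Among the measured compounds shown here, the step of a number 0.80 log units higher from compound 2 to compound 3 (beyond the scatter) is the only measured change at one place, and it concerns the same ring that is altered now.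

Compound 4, `Cc1ccccc1NC(=S)NC(=O)Nc1ccc2c(c1)C(=O)C(=O)N2Cc1ccccc1Cl`, differs from compound 3 by methyl in place of chloro on an aromatic carbon. For the measured compounds named here, no measured pair shows a methyl taking the place of a chloro, so the expectation rests on the fact that both groups are single heavy atoms without donors, acceptors or charge, and that compound 3 sits at the high end of the range after the chloro was added. For compound 4 the step of a number 0.18 log units lower from compound 3 to compound 4 (within the scatter) is expected to stay within the scatter, leaning slightly downward. In this assay compound 4 is estimated at 3.8, with a range from 3.4 to 4.2.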

Compound 4, partition coefficient: 3.7
Compound 4: the middle estimate sits 0.10 log units above what was measured; low and high end bracket the measured number.
By their numbers in this assay, from the lowest: compounds 1 and 2 (each within the scatter of the next); then compounds 4 and 3 (each within the scatter of the next).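

The step of a number 0.28 log units lower from compound 3 to compound 4 (within the scatter) shows that in this assay methyl and chloro cannot be told apart at this position on the thiourea phenyl ring. Both differ clearly from hydrogen there, with methyl giving the step of a number 0.52 log units higher from compound 2 to compound 4 (beyond the scatter) and chloro giving the step of a number 0.80 log units higher from compound 2 to compound 3 (beyond the scatter). Elsewhere in the molecule, chloro in place of hydrogen on an aromatic carbon gives the step of a number 0.72 log units higher from compound 1 to compound 4 (beyond the scatter), which also lies beyond the scatter.

Nothing available here explains why these two groups give such close numbers. Going by these compounds, how an amine, a carboxylic acid or a longer chain at this position would read in this assay remains open.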